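Methoxy for methyl on a quinazolinone-type series: an expectation

The compounds below may be only part of what the source reports. "The series", "measured", "known", "first", "only" and "open" are said of these compounds alone.

Of the compounds shown here, three sharing one core have been measured in an assay on isolated protein for inhibition of DNA topoisomerase 1 (Homo sapiens), with a stated time of 30 min, tested at 100 uM; a higher number here means a stronger effect of the compound at the concentration tested, a lower number a weaker effect. Compound 1 `Cc1ccc2nc(-c3ccccc3N(C)C)[nH]c(=O)c2c1` gives 82.9% in this assay. Compound 3 `Cc1ccc2c(=O)[nH]c(-c3ccccc3OC(F)(F)F)nc2c1` reaches 100% in this assay. Compound 2 `Cc1cccc(-c2nc3ccc(C)cc3c(=O)[nH]2)c1` stands lowest of the three with 75.7% in this assay; its nearest neighbour is compound 1, whose number lies within the scatter of it, while compound 3 lies beyond the scatter above it.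

Compound 4 `COc1cccc(-c2nc3ccc(C)cc3c(=O)[nH]2)c1` has not yet been measured. It differs from compound 2 in one place: methoxy in place of methyl on an aromatic carbon. Going by the values given here, no pair of measured compounds shows this change, so its size must be guessed. Among the compounds with values here, the step is small in terms of what is counted, and nothing among the measured compounds points either way with confidence.

Compound 4 is therefore expected to give about 78% in this assay, between 55% and 98%. The step of a number 2.3 percentage points higher from compound 2 to compound 4 (within the scatter) is estimated to stay within the usual scatter, with no clear direction.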

Compound 4, a percentage reported as inhibition, at one concentration (the size of the read-out at that concentration, not a potency): 71.8%
Estimate against measurement, compound 4: 6.2 percentage points above; low and high end bracket the measured number.
By their numbers in this assay, from the lowest: compounds 4, 2 and 1 (each within the scatter of the next, the first and the last beyond it); then compound 3.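

In this assay, going by these compounds alone, methoxy in place of methyl on an aromatic carbon, meta to a large group, gives a number 3.9 percentage points lower from compound 2 to compound 4 (within the scatter), the first direct reading of this change. It shows that, with the rest of the structure unchanged, adding one oxygen and a hydrogen-bond acceptor at this position does not shift the read-out beyond the usual variation between repeats. No measurement shown offers an explanation for this result.

Going by these compounds, whether an amine, a carboxylic acid or a longer chain at this same position would leave the read-out similarly unmoved remains open. So does whether methoxy in place of methyl would give a similar step on another carbon of this ring, or on a compound carrying a different group elsewhere on the shared core.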